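Methyl groups added to a fluorinated amide at the limit

The compounds below may be only part of what the source reports. "The series", "measured", "known", "first", "only" and "open" are said of these compounds alone.

Compound 3 `O=C(Nc1ccc(Oc2ccnc3[nH]ccc23)c(F)c1)c1cc(-c2ccccc2)ccn1` was tested in a functional assay on MCF7 cells (Homo sapiens) for cytotoxicity, read by MTT assay, with a stated time of 72 h; a lower number here means a stronger inhibitor, a higher number a weaker inhibitor. For compound 3 the result is only a limit of > 10000 nM, a value where (the limit of > 10000 nM in this assay, at which 2 of the 3 values shown sit). Its closest measured relative, compound 2 `O=C(Nc1ccc(Oc2ccnc3[nH]ccc23)cc1)c1cc(-c2ccccc2)ccn1`, gives 3750 nM. Within the data shown here, the step of an at least 2.6-fold higher number from compound 2 to compound 3 (0.42 log units; beyond the scatter) is the only measured change that touches compound 3. Compound 1 `CCc1ccc(-c2ccc(C(=O)Nc3ccc(Oc4ccnc5[nH]ccc45)cc3)nc2)cc1` shows only the limit of > 10000 nM. The new compound 4 `Cc1ccc(-c2ccnc(C(=O)Nc3ccc(Oc4ccnc5[nH]ccc45)c(F)c3)c2)c(C)c1` differs from compound 3 by 2,4-dimethylphenyl in place of phenyl on an aromatic carbon. Among the measured compounds shown here, no measured step involves a change of this kind, so the data give no guide to its direction. Compound 3 already sits at the limit. Compound 4 is expected to stay near that limit, with an estimated step that the limit leaves unreadable from compound 3 to compound 4. Compound 4 is therefore expected to give about 12000 nM, in the range 4000 nM to 40000 nM.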

Compound 4, half-maximal inhibitory concentration: 6220 nM
Compound 4: middle estimate off by 1.9-fold (0.29 log units), on the high side; measured number inside the range.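

Putting 2,4-dimethylphenyl in place of phenyl, opposite the ring nitrogen, gives an at least 1.6-fold lower number from compound 3 to compound 4 (0.20 log units; that floor lies within the scatter). This is the only measured change at this position, and it makes compound 4 the only fluoro compound shown with a number rather than a limit. From the compounds shown here alone, the value for compound 3 remains a limit, so the true size of this step stays unknown.

Going by these compounds, whether a single methyl, a methoxy group or an amine on this phenyl ring would shift the number stays open. So does how 2,4-dimethylphenyl behaves without the fluoro.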